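The source may report more compounds than this note shows. Statements on the series, on what has been measured and on what is new or still open speak of the compounds shown alone.

In a functional assay on MIA PaCa-2 cells (Homo sapiens) for inhibition, read by MTT assay, with a stated time of 48 h, tested at 10 uM (a lower number here means less inhibition of growth, a higher number more inhibition of growth at the concentration tested), three compounds built on one shared core have been measured. Compound 1 `Cc1cc(=O)c2c(O)c(CN3CCC(Cc4ccccc4)CC3)c(O)c([C@H]3CCN(C)C[C@H]3O)c2o1` gives 18%, compound 2 `Cc1cc(=O)c2c(O)c(CN(C)CC(=O)O)c(O)c([C@H]3CCN(C)C[C@H]3O)c2o1` gives 16%, and compound 3 `Cc1cc(=O)c2c(O)c(CN3CC(O)CC3C(=O)O)c(O)c([C@H]3CCN(C)C[C@H]3O)c2o1` gives 23%. Compound 3 thus lies within the scatter of both others, and the three numbers do not separate from one another.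

The next structure is compound 4 `Cc1cc(=O)c2c(O)c(CN3CCCCC3)c(O)c([C@H]3CCN(C)C[C@H]3O)c2o1`, which carries piperidin-1-yl in place of 2-carboxy-4-hydroxypyrrolidin-1-yl on a saturated chain carbon bound to an aromatic carbon. The difference counts out as piperidin-1-yl in place of 2-carboxy-4-hydroxypyrrolidin-1-yl on a saturated chain carbon bound to an aromatic carbon.

Among the measured compounds shown here, one measured step touches this same place: a number 7 percentage points higher from compound 2 to compound 3 (within the scatter). It exchanged one carboxy-bearing amino group for another, so it says little directly about losing the carboxy group. Compound 1 comes closer to that case, since it also has no carboxy group at this place, yet its number stays within the scatter of those of compound 2 and compound 3. For the measured compounds named here, none of the measured compounds therefore points to a large effect from this change, although three compounds are a narrow basis.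

No step beyond the scatter is expected, and the estimated change is a number 3 percentage points lower from compound 3 to compound 4 (within the scatter). The expected value for compound 4 is 20%, with an estimated range from 9% to 33%.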

Compound 4, percent growth inhibition at one concentration: 14%
Compound 4: the middle estimate sits 6 percentage points above what was measured, and the stated range covers the measured number.
By their numbers in this assay, from the lowest: compounds 4, 2, 1 and 3 (each within the scatter of the next).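

In this assay the plain piperidin-1-yl group of compound 4, which counts no hydrogen-bond donors, cannot be told apart from either carboxy-bearing amino group: the exchange gives a number 9 percentage points lower from compound 3 to compound 4 (within the scatter) and, against the open-chain group, a number 2 percentage points lower from compound 2 to compound 4 (within the scatter), so on this saturated chain carbon bound to an aromatic carbon neither the carboxy group nor the ring hydroxy group shows an effect that rises above the scatter. Hydrogen in place of benzyl on a saturated ring carbon gives a number 4 percentage points lower from compound 1 to compound 4 (within the scatter), so the benzyl group leaves no readable mark either. Nothing beyond the numbers themselves is at hand to bear on this result.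

Whether any group at this place can move the number beyond the scatter stays open, since a morpholin-4-yl ring, a simple primary amine and a longer chain ending in a carboxylic acid are not among the compounds shown. On these data alone, how these compounds would compare across a range of concentrations, rather than at the single one tested, also stays open.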